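A few compounds are considered here, and "the series" means these few. Any claim that something is new, unique, unknown or untested is made for them only; others in the source may bear on it.

Values in a toxicity assay on Huh-7.5 cells (Homo sapiens) for inhibition, read by MTT assay, with a stated time of 96 h; a lower number here means that less compound is tolerated, a higher number that more compound is tolerated:
- compound 1 `COc1ccc(NC(=O)c2ccc(OCCCCl)c([N+](=O)[O-])c2)cc1`: 39700 nM
- compound 2 `CCC(=O)Nc1cc(C(=O)Nc2ccc(OC)cc2)ccc1OCCCCl`: 158000 nM
- compound 3 `CCC(=O)Nc1cc(C(=O)Nc2ccc(N(C)C)cc2)ccc1OC(C)C`: 80600 nM

Compound 2 lies within the scatter of compound 3 and beyond the scatter from compound 1, whose number is lower. Compound 4 `CCC(=O)Nc1cc(C(=O)Nc2ccc(OC)cc2)ccc1OCCCN(C)C` has dimethylamino in place of chloro on a saturated chain carbon, three bonds along the chain from an oxygen on an aromatic ring. Within the data shown here, no measured step covers this exchange. The only one, a 4.0-fold higher number from compound 1 to compound 2 (0.60 log units; beyond the scatter), is modest and lies at another place on the shared core, so it suggests a size but no direction. Compound 2 stands at 158000 nM. Among the measured compounds shown here, no compound here stands beyond the scatter over compound 2, so a modest fall in this assay is expected. The expected step is a 2.4-fold lower number from compound 2 to compound 4 (0.39 log units; beyond the scatter). For compound 4 the estimate is 65000 nM, with an expected range of 22000 nM to 170000 nM.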

Compound 4, half-maximal cytotoxic concentration: 154000 nM
Estimate against measurement, compound 4: 2.4-fold (0.37 log units) below; the measured number falls inside the stated range.
By their numbers in this assay, from the lowest: compound 1; then compounds 3, 4 and 2 (each within the scatter of the next).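

In this assay, the exchange of 3-chloropropyl for 3-(dimethylamino)propyl gives a first step read at this position (a 1.0-fold lower number from compound 2 to compound 4 (0.01 log units; within the scatter)). Among these compounds, at this place on the shared core, the two groups are not told apart by this read-out, whereas the only earlier step, at another place, lay beyond the scatter (a 4.0-fold higher number from compound 1 to compound 2 (0.60 log units; beyond the scatter)). Nothing available offers an explanation for this result.

Open, as far as these compounds go, is whether a carboxylic acid, a morpholine or a longer chain carrying dimethylamino would also stay within the scatter of compound 2. Also open, from the compounds shown here alone, is whether the same exchange gives a similar step on other cores.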